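The source may hold more compounds than are shown below. What is called first, only, known or untested is meant among the compounds shown, and "the series" means these compounds.

Working notes on the series, all read in a functional assay on MGC-803 cells (Homo sapiens) for inhibition, read by MTT assay, with a stated time of 48 h; a lower number here means a stronger inhibitor, a higher number a weaker inhibitor. Compound 1 `COc1ccc(CN(C(C)=O)c2cc(OC)c(OC)c(OC)c2)cc1O` gives 79 nM, and compound 2 `COc1ccc(CN(C(=O)CCl)c2cc(OC)c(OC)c(OC)c2)cc1O` gives 84 nM. Among the compounds with values here, compound 2 therefore stands within the scatter of compound 1, the only other measured compound, and the two numbers carry no order.

Compound 3 `COc1ccc(CN(C(=O)CCCl)c2cc(OC)c(OC)c(OC)c2)cc1O` is the next to be read. Its difference from compound 2 is chloromethyl in place of chloro on a saturated chain carbon bound to a carbonyl carbon, or (chloromethyl)carbonyl to (2-chloroethyl)carbonyl when cut one bond further out.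

Within the data shown here, one measured step bears on this change: a 1.1-fold higher number from compound 1 to compound 2 (0.03 log units; within the scatter), with chloro in place of hydrogen on a saturated chain carbon bound to a carbonyl carbon. Among the measured compounds shown here, that step stays within the scatter, but it is a single step, and no measured compound carries the 2-chloroethyl group. No step beyond the scatter is expected in this assay, and no direction is favoured.

The expected step is a 1.1-fold higher number from compound 2 to compound 3 (0.03 log units; within the scatter). Compound 3 is estimated at 90 nM, with an expected range of 38 nM to 220 nM.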

Compound 3, half-maximal inhibitory concentration: 140 nM
Compound 3: the middle estimate sits 1.6-fold (0.19 log units) below what was measured, and the stated range covers the measured number.
By their numbers in this assay, from the lowest: compounds 1, 2 and 3 (each within the scatter of the next).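

In this assay, within the data shown here, chloromethyl in place of chloro on a saturated chain carbon bound to a carbonyl carbon gives a 1.7-fold higher number from compound 2 to compound 3 (0.22 log units; within the scatter) and is the first measured step at this place that involves the 2-chloroethyl group. Measured against the compound with only hydrogen at that carbon, chloromethyl in place of hydrogen gives a 1.8-fold higher number from compound 1 to compound 3 (0.25 log units; within the scatter) and so extends the reading across all three compounds, each of which stays within the scatter of the others, with no order among them. No measurement bears on why these numbers stand as they do.

The compounds shown leave open whether a longer chain ending in chloro, or an amine or a carboxylic acid in place of the chloro, would stay within the scatter at this place. They also leave open whether a plain ethyl group without chlorine would read like the 2-chloroethyl group, so any separate contribution of the chlorine and the chain at this place remains unresolved.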